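Dichlorophenyl for pyridinyl on a quinoline carboxamide piperazine

The source may hold more compounds than are shown below. What is called first, only, known or untested is meant among the compounds shown, and "the series" means these compounds.

This account follows a single change within a series of arylpiperazine carboxamides. Compound 2 `O=C(NCCCN1CCN(c2ccccn2)CC1)c1ccc2ccccc2n1` carries a pyridin-2-yl group on the piperazine nitrogen and a quinoline carboxamide at the other end of the propyl chain. In an assay on HEK293 cells for inhibition of sodium-dependent dopamine transporter (Homo sapiens), read by scintillation counting (a higher number here means a weaker inhibitor, a lower number a stronger inhibitor), compound 2 reaches only the limit of the assay, > 10000 nM, so no number is available for it. Compound 1 `O=C(NCCCN1CCN(c2cccc(Cl)c2Cl)CC1)c1ccc2ccccc2c1`, the naphthalene carboxamide, likewise sits at the limit with > 10000 nM in this assay. Both values thus rest on (the limit of > 10000 nM in this assay, at which 2 of the 2 values shown sit), and compound 2 cannot be placed above or below compound 1 on these numbers.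

Compound 3 `O=C(NCCCN1CCN(c2cccc(Cl)c2Cl)CC1)c1ccc2ccccc2n1` is the change of interest: 2,3-dichlorophenyl in place of pyridin-2-yl on an amine nitrogen in a ring. Since the shared dichlorophenylpiperazine of compound 1 and the shared quinoline carboxamide of compound 2 each sit at the limit, compound 3 is expected to show no step beyond the scatter, the expected step from compound 2 to compound 3 being a step that the limit leaves unreadable from compound 2 to compound 3 in this assay. Compound 3 is therefore estimated at 15000 nM, within 4000 nM to 60000 nM, most likely again reported only as a limit.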

Compound 3, half-maximal inhibitory concentration: > 10000 nM
Compound 3: a limit, no number (the forecaster's own chance of this, stated with the estimate: 75%); the middle value is on the limit's open side.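

In this assay compound 3 gives > 10000 nM, which is a limit and not a number. No step can be read from compound 2 to compound 3 or from compound 1 to compound 3, because all three compounds rest on the same limit: the limit of > 10000 nM in this assay, at which 3 of the 3 values shown sit.

The compounds shown leave open whether either exchange alters the half-maximal inhibitory concentration at all.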